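The source may report more compounds than this note shows. Statements on the series, on what has been measured and on what is new or still open speak of the compounds shown alone.

Of the compounds shown here, three have been measured in a functional assay on RPMI8266 cells (Homo sapiens) for inhibition, read by sulforhodamine B assay, with a stated time of 48 h; on this read-out lower numbers stand for stronger inhibition of growth and higher numbers for weaker inhibition of growth: compound 1 `COc1cc(C)cc(-c2nn(CC#N)cc2-c2ccc(-c3cccc(C(C)=O)c3)nc2)c1`, compound 2 `Cc1cc(O)cc(-c2nn(CC#N)cc2-c2ccnc(-c3ccc(Oc4ccccc4)cc3)c2)c1` and compound 3 `COc1cc(C)cc(-c2nn(CC#N)cc2-c2ccnc(-c3ccc(N(C)C)cc3)c2)c1`. In this assay compound 1 gives 18600 nM, compound 2 gives 6520 nM, and compound 3 gives 10700 nM. Compound 3 thereby holds the second highest of the three numbers, with compound 2 nearest and compound 1 furthest, both gaps within the scatter of repeated measurements. No order among the three is claimed.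

Compound 4 `Cc1cc(O)cc(-c2nn(CC#N)cc2-c2ccnc(-c3ccc(N(C)C)cc3)c2)c1` has not yet been measured. It differs from compound 3 by hydrogen in place of methyl on an oxygen on an aromatic ring, that is, methoxy to hydroxy, 3-methoxy-5-methylphenyl to 3-hydroxy-5-methylphenyl. Going by the values given here, no measured pair shows this change on its own. Compound 2 carries the hydroxy form together with a different group on the other ring, and its value and that of compound 3 sit within the scatter of each other; that is the only hint at hand. A step from compound 3 to compound 4 of a 1.1-fold lower number from compound 3 to compound 4 (0.05 log units; within the scatter) is expected, with no direction beyond the scatter. Compound 4 is accordingly estimated at 9500 nM, with a range from 4000 nM to 22000 nM.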

Compound 4, concentration for total growth inhibition: 22200 nM
Beside the measured number, compound 4's estimate is 2.3-fold (0.37 log units) below it; measured number outside the range, above it.
By their numbers in this assay, from the lowest: compounds 2, 3, 1 and 4 (each within the scatter of the next, the first and the last beyond it).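

In this assay, the methoxy to hydroxy change on the aromatic ring can now be read on its own: with the dimethylamino group held constant, hydrogen in place of methyl on the oxygen gives a 2.1-fold higher number from compound 3 to compound 4 (0.32 log units; beyond the scatter), a modest loss of growth inhibition beyond the scatter. With the hydroxy form held constant, dimethylamino in place of phenoxy gives a 3.4-fold higher number from compound 2 to compound 4 (0.53 log units; beyond the scatter), so the hydroxy form does not set the level alone, and the outcome at the oxygen can only be stated for the dimethylamino partner so far. No measurement at hand accounts for either step.

It remains open whether hydrogen in place of methyl on the oxygen gives a step of similar size with phenoxy in place of dimethylamino, as the compounds shown include no methoxy partner of compound 2. They also leave open whether a longer chain on the oxygen, such as ethoxy, or an amine in place of the hydroxy group would carry the trend beyond this single pair.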